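A few compounds are considered here, and "the series" means these few. Any claim that something is new, unique, unknown or untested is made for them only; others in the source may bear on it.

Three close relatives of one piperidine-bearing acetal have been tested in a functional assay (brain) for displacement of a labelled ligand, with Rattus norvegicus as the target; on this read-out lower numbers stand for stronger inhibition and higher numbers for weaker inhibition. Compound 1 `CC[C@]1(c2ccccc2O)OC[C@H]([C@@H]2CCCCN2)O1` gives 293 nM. Among the measured compounds shown here, compound 3 `CC[C@]1(c2ccccc2F)OC[C@H]([C@@H]2CCCCN2)O1` gives 36 nM, and the single change between them, (fluoro in place of hydroxy on an aromatic carbon), made an 8.1-fold lower number from compound 1 to compound 3 (0.91 log units; beyond the scatter). Compound 2 `CC[C@]1(c2ccc(O)cc2)OC[C@H]([C@@H]2CCCCN2)O1` gives 19900 nM; it is built from the same atoms as compound 1, joined differently, and the difference between the two cores is not broken down here. Compound 4 `CC[C@]1(c2ccc(F)cc2)OC[C@H]([C@@H]2CCCCN2)O1` is not yet measured; it arises from compound 2 by fluoro in place of hydroxy on an aromatic carbon, the same kind of change as before, but now para to a large group rather than ortho to it. Because that earlier change gave an 8.1-fold lower number from compound 1 to compound 3 (0.91 log units; beyond the scatter), a gain of similar size is expected from compound 2 to compound 4, a 6.6-fold lower number from compound 2 to compound 4 (0.82 log units; beyond the scatter), though the different place adds uncertainty. Compound 4 is therefore estimated at 3000 nM, with 700 nM to 13000 nM as the likely span.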

Compound 4, inhibition constant: 649 nM
For compound 4 the middle estimate is 4.6-fold (0.66 log units) above the measured one, and the stated range ends above it.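

Putting fluoro in place of hydroxy again lowers the number in this assay, with a 31-fold lower number from compound 2 to compound 4 (1.49 log units; beyond the scatter), so the direction of the change carries over to the second core. The size of the change does not carry over: the same change on two cores in this assay, an 8.1-fold lower number (0.91 log units; beyond the scatter) from compound 1 to compound 3 and a 31-fold lower number (1.49 log units; beyond the scatter) from compound 2 to compound 4, 3.8-fold (0.58 log units) apart, beyond the scatter of two such steps. Among the compounds shown here, with only two pairs, this shows a shared direction but does not explain the gap in size or show how large the step would be on any other core.

Going by these compounds, only hydroxy and fluoro appear on the aromatic ring here, so it remains open how a chloro or methoxy group in the same place would compare. On these data alone, it also remains open whether these steps would hold with a longer chain in place of the ethyl group.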